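From compound 1 to compound 4: one group exchanged

A few compounds are considered here, and "the series" means these few. Any claim that something is new, unique, unknown or untested is made for them only; others in the source may bear on it.

- Compound 1 `Nc1ncnc2c1c(-c1cc3ccccc3o1)cn2[C@H]1CCN(C[C@@H]2CO2)C1`: 6740 nM
- Compound 2 `Nc1ncnc2c1c(-c1cc3ccccc3o1)cn2[C@H]1CCN(C[C@H]2CO2)C1`: 1650 nM
- Compound 3 `Nc1ncnc2c1c(-c1ccc(Oc3ccccc3)cc1)cn2[C@H]1CCN(C[C@@H]2CO2)C1`: 6710 nM

In a functional assay on Ramos cells (Homo sapiens) for antiproliferative activity (on this read-out lower numbers stand for stronger inhibition and higher numbers for weaker inhibition), compound 1 gives 6740 nM and compound 3 gives 6710 nM, two values within the usual scatter of each other. Together they form the high, weaker end of the three numbers, with compound 2 clearly lower at 1650 nM.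

Compound 4 `Nc1ncnc2c1c(-c1cnc3[nH]ccc3c1)cn2[C@H]1CCN(C[C@@H]2CO2)C1` has not yet been measured. It loses the 1-benzofuran-2-yl group of compound 1 and keeps the rest of the structure: a group of 9 heavy atoms (7 carbon, 2 nitrogen; one five-membered aromatic ring with 1 hetero atom, one six-membered aromatic ring with 1 hetero atom) in place of a group of 9 heavy atoms (8 carbon, 1 oxygen; one five-membered aromatic ring with 1 hetero atom, one six-membered aromatic ring of carbon only), on an aromatic carbon.

Going by the values given here, the only measured step is a 4.1-fold lower number from compound 1 to compound 2 (0.61 log units; beyond the scatter). It comes with the fact that compounds 1 and 2 differ only in the configuration as drawn, so it does not speak to this exchange. The closer guide has the same drawn configuration as compound 1 and another group at this place: this is compound 3, which gives 6710 nM. One such comparison is thin evidence, so the range stays wide.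

No step beyond the scatter is expected in this assay, and the estimated change is a 1.3-fold lower number from compound 1 to compound 4 (0.13 log units; within the scatter). For compound 4 the estimated value is 5000 nM. The expected range runs from 1500 nM to 15000 nM.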

Compound 4, half-maximal inhibitory concentration: 4650 nM
The estimate for compound 4 lay 1.1-fold (0.03 log units) above the measured number, and the stated range covers the measured number.
By their numbers in this assay, from the lowest: compound 2; then compounds 4, 3 and 1 (each within the scatter of the next).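

The exchange of the 1-benzofuran-2-yl group for a group with two ring nitrogens and a hydrogen-bond donor gives a 1.4-fold lower number from compound 1 to compound 4 (0.16 log units; within the scatter) in this assay, so adding that donor and swapping the ring oxygen for nitrogens does not shift the number measurably. With compound 3, this makes three different aromatic groups at this place, all with the same drawn configuration, whose numbers sit within the scatter of one another. Nothing measured here explains why the exchange leaves the number unmoved.

A small group at this place, such as an amine, a carboxylic acid or a longer chain, remains untested among the compounds shown. Also open, going by these compounds, is whether the lower number of compound 2, with its other drawn configuration, would carry over to the group of compound 4.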